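This account rests on a few compounds, and the source may have more. Where it says the series, first, only, none or still open, it means among the compounds named here.

In an ADME assay on HEK293 cells (Homo sapiens) for cytotoxicity, read by MTT assay, with a stated time of 24 h (a higher number here means a weaker inhibitor, a lower number a stronger inhibitor), three compounds with a shared core have numbers: compound 1 `CN(C)CCCNc1nc2cc([N+](=O)[O-])ccc2nc1NCc1ccc(C(F)(F)F)cc1` gives 5.66 ug/mL, compound 2 `CN(C)CCCNc1nc2cc([N+](=O)[O-])ccc2nc1NCc1ccc(Br)cc1` gives 9.63 ug/mL and compound 3 `CN(C)CCCNc1nc2cc([N+](=O)[O-])ccc2nc1NCc1cccc(C(F)(F)F)c1` gives 7.99 ug/mL. All three lie within the usual scatter of one another, so compound 3 cannot be separated from the other two. Compound 4 `CN(C)CCCNc1nc2cc([N+](=O)[O-])ccc2nc1NCc1ccc(Cl)c(C(F)(F)F)c1` has chloro in place of hydrogen on an aromatic carbon of compound 3, ortho to a trifluoromethyl group and para to a large group (chloro in place of hydrogen on an aromatic carbon). Within the data shown here, no measured step adds a group to the ring, but three alter its substituents: a 1.7-fold higher number from compound 1 to compound 2 (0.23 log units; within the scatter), a 1.4-fold higher number from compound 1 to compound 3 (0.15 log units; within the scatter) and a 1.2-fold lower number from compound 2 to compound 3 (0.08 log units; within the scatter). On that limited evidence, no change beyond the scatter is expected, and the estimated step is a 1.2-fold lower number from compound 3 to compound 4 (0.09 log units; within the scatter). Compound 4 is expected at 6.5 ug/mL, within an estimated range of 3.5 ug/mL to 12 ug/mL.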

Compound 4, half-maximal inhibitory concentration: 3.26 ug/mL
Compound 4: middle estimate off by 2.0-fold (0.30 log units), on the high side; measured number below the stated range.
By their numbers in this assay, from the lowest: compounds 4, 1, 3 and 2 (each within the scatter of the next, the first and the last beyond it).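

Earlier swaps of ring substituents stayed within the scatter, but adding chloro ortho to a trifluoromethyl group gives a 2.5-fold lower number from compound 3 to compound 4 (0.39 log units; beyond the scatter) in this assay. The 4-chloro-3-(trifluoromethyl)phenyl group also gives a 3.0-fold lower number from compound 2 to compound 4 (0.47 log units; beyond the scatter) when it replaces 4-bromophenyl, whereas a 1.7-fold lower number from compound 1 to compound 4 (0.24 log units; within the scatter) leaves that pair unseparated. Nothing available explains the lower number.

Going by these compounds, whether this step is specific to chloro stays open. A fluoro, methyl or methoxy group at the same place could show whether other groups give a similar step.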